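Adding a phenyl group on the ester side of an enamide

The source may report more compounds than this note shows. Statements on the series, on what has been measured and on what is new or still open speak of the compounds shown alone.

Measured so far:
compound 1, `COC(=O)/C=C\NC(=O)[C@@H](O)C(C)(C)CO`: -12%
compound 2, `COC(=O)/C=C\NC(=O)[C@H](O)C(C)(C)CO`: "not determined" (no result reported)
compound 3, `CC(C)(C)OC(=O)/C=C/NC(=O)[C@@H](O)C(C)(C)CO`: -8%

All three compounds share the same core, a hydroxy amide attached to an unsaturated ester. They were tested in an ADME assay on HEK293 cells (Homo sapiens) for inhibition, read by CellTiter-Glo, with a stated time of 96 h, tested at 100 uM; on this read-out higher numbers stand for more inhibition at the one concentration tested (going by the name of the read-out) and lower numbers for less inhibition. Compound 1 gives -12%, and compound 3 gives -8%; these two lie within the usual scatter of each other, so neither can be placed above the other, and both sit close to no inhibition at all. Compound 2 gives "not determined" (no result reported) in this assay, and the fact that compounds 1 and 2 differ only in the configuration as drawn is all the structures say about that pair.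

The unmeasured compound 4, `CC(C)(CO)[C@H](O)C(=O)N/C=C\C(=O)OCc1ccccc1`, differs from compound 1 by phenyl in place of hydrogen on a saturated chain carbon bound to an oxygen next to a carbonyl group. Going by the values given here, with only two numbers available and no measured step between them, the data give no direction for this change. Since compound 1 and compound 3 already carry different ester groups without a difference beyond the scatter, the step of a number 7 percentage points higher from compound 1 to compound 4 (within the scatter) is expected to stay within the scatter as well. Compound 4 is therefore expected to give -5%, with a likely range from -20% to 15%.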

Compound 4, a percentage reported as inhibition, at one concentration (the size of the read-out at that concentration, not a potency): -7%
For compound 4 the middle estimate is 2 percentage points above the measured one; the range from low to high includes it.
By their numbers in this assay, from the lowest: compounds 1, 3 and 4 (each within the scatter of the next).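

Putting phenyl in place of hydrogen on a saturated chain carbon bound to an oxygen next to a carbonyl group, a change that can also be read as methyl to benzyl, gives in this assay a number 5 percentage points higher from compound 1 to compound 4 (within the scatter) and so leaves the read-out within its usual scatter. Going by these compounds alone, this is the first step between measured compounds that differ in only one place, and it shows that this position can carry phenyl without a readable change in inhibition at the one concentration tested, which the earlier compounds could not show. Nothing available here bears on why this step has the size it has.

Going by these compounds, a single group at this position says little about others, so it remains open whether an amine, a carboxylic acid or a longer chain in place of phenyl would also stay within the scatter in this assay. On these data alone, the step between compound 1 and compound 2 cannot be read, so the role of the configuration as drawn also stays open.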